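This account rests on a few compounds, and the source may have more. Where it says the series, first, only, none or still open, it means among the compounds named here.

Measured in a functional assay on THP-1 cells (Homo sapiens); on this read-out higher numbers stand for larger maximal responses and lower numbers for smaller maximal responses:

compound 1 `CCSC[C@@](O)([C@@H](Nc1cccc2nc(C)ccc12)c1ccc(OC)cc1)C(F)(F)F`: 86%
compound 2 `CCSC[C@@](O)([C@@H](Nc1cccc2nc(C)ccc12)c1ccc(OC)cc1F)C(F)(F)F`: 85%
compound 3 `CCSC[C@@](O)([C@@H](Nc1cccc2nc(C)ccc12)c1ccc(OC)c(F)c1)C(F)(F)F`: 82%

Compound 3 carries the lowest of the three figures, but both gaps to it are small: a number 4 percentage points lower from compound 1 to compound 3 (within the scatter) and a number 3 percentage points lower from compound 2 to compound 3 (within the scatter). Likewise a number 1 percentage points lower from compound 1 to compound 2 (within the scatter). All three measured steps concern a fluoro in place of hydrogen on an aromatic carbon, or the exchange of 2-fluoro-4-methoxyphenyl for 3-fluoro-4-methoxyphenyl, and none of them moves the maximal response beyond the scatter.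

Compound 4 `CCSC[C@@](O)([C@@H](Nc1cccc2nc(C)ccc12)c1ccc(Cl)c(F)c1OC)C(F)(F)F` is not yet measured. It differs from compound 3 as follows: 4-chloro-3-fluoro-2-methoxyphenyl in place of 3-fluoro-4-methoxyphenyl on a saturated chain carbon bound to a nitrogen on an aromatic ring and a saturated chain carbon. Two parts of this change, the chloro and the shifted methoxy, are not covered by any measured step; only the fluoro on the ring has a precedent, and that precedent gave no step beyond the scatter. Nothing measured therefore argues for a move in either direction in this assay.

Compound 4 is expected to give 81%, with a range of 70% to 92%. This corresponds to an expected step of a number 1 percentage points lower from compound 3 to compound 4 (within the scatter), within the scatter.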

Compound 4, largest response reached (Emax), in percent of the reference or control that the assay uses: 82%
Beside the measured number, compound 4's estimate is 1 percentage points below it; the range from low to high includes it.
By their numbers in this assay, from the lowest: compounds 3, 4, 2 and 1 (each within the scatter of the next).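

In this assay, the position on the saturated chain carbon bound to a nitrogen on an aromatic ring and a saturated chain carbon now takes a larger exchange than a single fluoro: 4-chloro-3-fluoro-2-methoxyphenyl in place of 3-fluoro-4-methoxyphenyl gives no change at the digits printed from compound 3 to compound 4 (within the scatter). The comparisons with the other two aryl groups read the same way, with a number 3 percentage points lower from compound 2 to compound 4 (within the scatter) and a number 4 percentage points lower from compound 1 to compound 4 (within the scatter), so the chloro and the shifted methoxy, introduced together, leave the maximal response within the scatter of all three earlier compounds. No measurement at hand offers an explanation for this result.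

The separate contributions of the chloro and the shifted methoxy remain unresolved. Also open, as far as these compounds go, is whether the response holds with a nitrile, an amine or a carboxylic acid on this ring.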